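A few compounds are considered here, and "the series" means these few. Any claim that something is new, unique, unknown or untested is made for them only; others in the source may bear on it.

Three compounds have been measured in a functional assay on DLA cells (Mus musculus) for cytotoxicity, read by MTT assay, with a stated time of 48 h; a higher number here means a weaker inhibitor, a lower number a stronger inhibitor:

Compound 1 `Cc1cc(C(=O)c2ccccc2)ccc1OCC(=O)Nc1nc(-c2ccccc2)cs1` gives 22300 nM.
Compound 2 `COc1ccc(-c2csc(NC(=O)COc3ccc(C(=O)c4ccccc4)cc3C)n2)cc1` gives 25700 nM.
Compound 3 `O=C(COc1ccc(C(=O)c2ccccc2)cc1Br)Nc1nc(-c2ccccc2)cs1` gives 43100 nM.

Compound 1 gives the lowest of the three numbers, but its steps to the other two, a 1.2-fold higher number from compound 1 to compound 2 (0.06 log units; within the scatter) and a 1.9-fold higher number from compound 1 to compound 3 (0.29 log units; within the scatter), both lie within the scatter, so the three compounds cannot be told apart on these data. The two measured steps show that a methoxy entering on an aromatic carbon, and a bromo replacing a methyl on an aromatic carbon, each left the number essentially unchanged.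

The step from compound 1 to compound 4 `Cc1cc(C(=O)c2ccccc2C)ccc1OCC(=O)Nc1nc(-c2ccccc2)cs1` is a change of the same modest kind: methyl in place of hydrogen on an aromatic carbon. This change sits on the benzoyl part of the shared core, on a six-membered aromatic ring of carbon only, ortho to a large group. Since neither of the measured steps, a 1.2-fold higher number from compound 1 to compound 2 (0.06 log units; within the scatter) nor a 1.9-fold higher number from compound 1 to compound 3 (0.29 log units; within the scatter), moved the number beyond the scatter, a single added methyl is not expected to either, and the step expected in this assay is a 1.1-fold higher number from compound 1 to compound 4 (0.03 log units; within the scatter), with no clear direction. Compound 4 is therefore estimated at 24000 nM, within a range from 12000 nM to 48000 nM.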

Compound 4, half-maximal inhibitory concentration: 23100 nM
Compound 4: the middle estimate sits 1.0-fold (0.02 log units) above what was measured; the measured number falls inside the stated range.
By their numbers in this assay, from the lowest: compounds 1, 4, 2 and 3 (each within the scatter of the next).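

In this assay, the added methyl gives a 1.0-fold higher number from compound 1 to compound 4 (0.02 log units; within the scatter), so compound 1 and compound 4 cannot be told apart. This is the only step shown on the benzoyl part of the molecule, where phenyl becomes 2-methylphenyl, and it shows that this part can carry one extra methyl, on an aromatic carbon ortho to a large group, without a measurable difference in this cell test. Together with the two earlier steps, it means that small substitutions at three different places on the shared core have not yet produced a difference beyond the scatter, although none of these data explain why the methyl makes no measurable difference here.

On these data alone, what remains open is whether something other than a methyl at this same position, such as an amine, a carboxylic acid or a longer chain, would give a number clearly separated from that of compound 1. As far as these compounds go, it is also open whether a methyl placed elsewhere on this ring would behave as it does in compound 4, since this single step speaks for one position and one small group only.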